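The source may hold more compounds than are shown below. What is called first, only, known or untested is meant among the compounds shown, and "the series" means these compounds.

Compound 3, `CCOC(=O)CCCCCOc1cccc(CN(C(=O)c2ccc(-c3ccoc3)cc2)C(C)C)c1`, has been measured in an ADME assay on BJ cells (Homo sapiens) for cytotoxicity, read by CellTiter-Glo and resazurin assay, with a stated time of 72 h; on this read-out higher numbers stand for an effect only at larger amounts of compound and lower numbers for an effect already at smaller amounts. In this assay compound 3 gives only a limit, > 26000 nM, and no number. Its two neighbours that differ from it in one place are compound 1, `CC(C)N(Cc1cccc(OCCCCCC(=O)O)c1)C(=O)c1ccc(-c2ccoc2)cc1`, and compound 2, `CC(C)N(Cc1cccc(OCCCCCC(=O)O)c1)C(=O)c1ccc(-c2cccc(O)c2)cc1`. In this assay compound 1 likewise gives a limit, > 26000 nM. In this assay compound 2 also gives a limit, > 26000 nM. The step that the two limits leave unreadable from compound 1 to compound 2 and the step that the two limits leave unreadable from compound 1 to compound 3 are thus unreadable in size because of the limit of > 26000 nM in this assay, at which 3 of the 3 values shown sit. Compound 4, `CCOC(=O)CCCCCOc1cccc(CN(C(=O)c2ccc(-c3ccc(Cl)c(Cl)c3)cc2)C(C)C)c1`, differs from compound 3 by the change (3,4-dichlorophenyl in place of furan-3-yl on an aromatic carbon). Among the compounds with values here, none of the measured steps exchanges the furan-3-yl for a 3,4-dichlorophenyl, and none of them has a readable size, so neither a direction nor a size of step in this assay can be drawn from them. It is expected that this assay will again report only a limit for compound 4. The estimate for compound 4 in this assay is 30000 nM, with an expected range from 8000 nM to 100000 nM. This corresponds to an expected step that the limit leaves unreadable from compound 3 to compound 4, which is not expected to go beyond the scatter.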

Compound 4, half-maximal effective concentration: > 26000 nM
Compound 4: no number, only a limit; the forecaster's own chance of this, stated with the estimate: 70%; the middle value lies beyond the limit too.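

No size can be read for the change from compound 3 to compound 4 in this assay, because both compounds give only a limit there: the limit of > 26000 nM in this assay, at which 4 of the 4 values shown sit.

The compounds shown leave open how 3,4-dichlorophenyl in place of furan-3-yl would shift a read-out in this assay that gives a number rather than a limit.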